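A few compounds are considered here, and "the series" means these few. Any claim that something is new, unique, unknown or untested is made for them only; others in the source may bear on it.

Among the compounds with values here, in an assay on HEK293 cells for positive allosteric modulation of metabotropic glutamate receptor 3 (Rattus norvegicus), read by thallium flux, with a stated time of 2.5 min (on this read-out lower numbers stand for smaller maximal responses and higher numbers for larger maximal responses), compound 3 `Cc1c(OCCCCOc2cccc(C(=O)O)c2)ccc(C(=O)CC(C)C)c1O` gives 69.9%, the highest of the three numbers measured so far. Compound 1 `Cc1c(OCCCCOc2ccc(C(=O)O)cc2Cl)ccc(C(=O)CC(C)C)c1O` gives 62.9%, and the step of a number 7 percentage points higher from compound 1 to compound 3 (within the scatter) stays within the scatter. Compound 2 `Cc1c(OCCCCOc2ccc(C(=O)O)c(Cl)c2)ccc(C(=O)CC2CCCC2)c1O` gives 40%, well below compound 3. Compound 4 `Cc1c(OCCCCOc2ccc(C(=O)O)c(Cl)c2)ccc(C(=O)CC(C)C)c1O` is not yet measured; it differs from compound 3 in one place: 4-carboxy-3-chlorophenyl in place of 3-carboxyphenyl on an oxygen on a saturated carbon. Within the data shown here, the only measured step bearing on this change is a number 7 percentage points higher from compound 1 to compound 3 (within the scatter), which exchanged the 4-carboxy-2-chlorophenyl for the 3-carboxyphenyl and was small. Among the measured compounds shown here, compound 2 carries the 4-carboxy-3-chlorophenyl on a different ketone side chain and sits far lower, but no single-change step links it to compound 3. A modest drop is therefore expected, a number 14.9 percentage points lower from compound 3 to compound 4 (beyond the scatter). Compound 4 is estimated at 55%, within 38% to 72%.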

Compound 4, largest response reached (reported as percent of maximum), in percent of the reference or control that the assay uses: 49.5%
The estimate for compound 4 lay 5.5 percentage points above the measured number, and the stated range covers the measured number.
By their numbers in this assay, from the lowest: compounds 2 and 4 (each within the scatter of the next); then compounds 1 and 3 (each within the scatter of the next).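

On the oxygen on a saturated carbon, the 4-carboxy-3-chlorophenyl gives a number 20.4 percentage points lower from compound 3 to compound 4 (beyond the scatter) and a number 13.4 percentage points lower from compound 1 to compound 4 (beyond the scatter) in this assay so this group separates from both other aryl groups. Isopropyl in place of cyclopentyl gives a number 9.5 percentage points higher from compound 2 to compound 4 (within the scatter) so the low number of compound 2 goes with its aryl group, not clearly with its side chain. Nothing measured here explains these differences. Still open, from the compounds shown here alone, is whether the 3-carboxyphenyl would hold its response with the cyclopentyl side chain. Also open, going by these compounds, is how a tetrazole in place of the carboxylic acid would read.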